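This account rests on a few compounds, and the source may have more. Where it says the series, first, only, none or still open, it means among the compounds named here.

Compound 1 `CCN(Cc1ccc(Br)cc1)c1cccc(C(=O)N2CCc3ccc(OS(N)(=O)=O)cc3C2)c1` carries a (4-bromobenzyl)(ethyl)amino group on an aromatic ring attached to the shared core. Going by the values given here, in an assay on HEK293 cells for inhibition of Steryl-sulfatase (Homo sapiens), tested at 0.1 uM (on this read-out lower numbers stand for a weaker effect and higher numbers for a stronger effect at the one concentration tested), compound 1 gives 24.2%, the highest of the two numbers measured so far. Among the compounds with values here, the only other measured compound, compound 2 `NS(=O)(=O)Oc1ccc2c(c1)CN(C(=O)c1ccc(N3CCC(N4CCCCC4)CC3)cc1)CC2`, has a different outer group, and in this assay compound 2 gives 8.5%, a weaker effect that lies beyond the usual scatter. Within the data shown here, no single-point step between measured compounds is available, so the two values can only be compared as they stand.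

Compound 3 `CN(C)CCN(CCN(C)C)c1cccc(C(=O)N2CCc3ccc(OS(N)(=O)=O)cc3C2)c1` has not yet been measured. It differs from compound 1 in one place: bis(2-(dimethylamino)ethyl)amino in place of (4-bromobenzyl)(ethyl)amino on an aromatic carbon. Among the measured compounds shown here, with no measured pair showing this kind of swap, the expectation is cautious: the one measured change away from compound 1 led to a weaker effect, and the size of the change here is large. A fall beyond the scatter is expected, of moderate size. Compound 3 is expected to give about 11%, with a likely range from 2% to 24%. That estimate corresponds to a step of a number 13.2 percentage points lower from compound 1 to compound 3 (beyond the scatter), expected to run downward.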

Compound 3, a percentage reported as inhibition, at one concentration (the size of the read-out at that concentration, not a potency): 0%
Compound 3: middle estimate off by 11 percentage points, on the high side; the whole stated range lies above it.
By their numbers in this assay, from the lowest: compounds 3 and 2 (each within the scatter of the next); then compound 1.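

In this assay, placing bis(2-(dimethylamino)ethyl)amino in place of (4-bromobenzyl)(ethyl)amino on this aromatic carbon, meta to a large group, gives a number 24.2 percentage points lower from compound 1 to compound 3 (beyond the scatter). Going by these compounds alone, this is the first single-place step, and it shows that the read-out at the one tested concentration depends on what sits at this position. The two groups have the same heavy-atom count, so matching that count alone does not preserve the effect, but nothing measured here explains the fall.

The swap removes an aromatic ring and a bromine and adds two nitrogens in one move, so the compounds shown cannot say which of these differences matters. A plain benzyl(ethyl)amino group would test the bromine on its own, while a (2-(dimethylamino)ethyl)(ethyl)amino group would test a single dimethylamino chain without the aromatic ring.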